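This account rests on a few compounds, and the source may have more. Where it says the series, first, only, none or still open, it means among the compounds named here.

Series notes. Compound 1 `CCCCCc1ccc2[nH]c(-c3ccc(OC)cc3)c(C=O)c2c1` gives 5.5 nM in a functional assay on MDA-MB-231 cells (Homo sapiens) for antiproliferative activity, with a stated time of 4 days; on this read-out lower numbers stand for stronger inhibition and higher numbers for weaker inhibition. Compound 2 `CCCCCc1ccc2[nH]c(-c3ccc(C(F)(F)F)cc3)c(C=O)c2c1` gives 42 nM in this assay, the change being (trifluoromethyl in place of methoxy on an aromatic carbon); that step is a 7.6-fold higher number from compound 1 to compound 2 (0.88 log units; beyond the scatter). Compound 3 `CCCCc1ccc2[nH]c(-c3ccc(OC)cc3)c(/C=N\O)c2c1` gives 40 nM in this assay; its values sit close to those of compound 2, while compound 1 stands lower than both. The difference between the core of compound 3 and the core of compound 1 is not broken down here. Compound 4 `CCCCc1ccc2[nH]c(-c3ccc(C(F)(F)F)cc3)c(/C=N\O)c2c1` is not yet measured; it differs from compound 3 by trifluoromethyl in place of methoxy on an aromatic carbon, the same change as from compound 1 to compound 2. For the measured compounds named here, the step from compound 3 to compound 4 is expected to be a 6.3-fold higher number from compound 3 to compound 4 (0.80 log units; beyond the scatter), resting on the single earlier instance a 7.6-fold higher number from compound 1 to compound 2 (0.88 log units; beyond the scatter), with the caveat that it occurs only once and on another core. Compound 4 is therefore estimated at 250 nM in this assay.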

Compound 4, half-maximal inhibitory concentration: 497 nM
Beside the measured number, compound 4's estimate is 2.0-fold (0.30 log units) below it; the range from low to high includes it.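

In this assay, trifluoromethyl in place of methoxy on an aromatic carbon gives a 12-fold higher number from compound 3 to compound 4 (1.09 log units; beyond the scatter) and so moves the number the same way as on the other core, with no difference in size that stands out from the scatter: the same change on two cores in this assay, a 7.6-fold higher number (0.88 log units; beyond the scatter) from compound 1 to compound 2 and a 12-fold higher number (1.09 log units; beyond the scatter) from compound 3 to compound 4, 1.6-fold (0.21 log units) apart, within the scatter of two such steps. In these two pairs, the change carries over from the core of compound 1 to the core of compound 3. Two pairs in one assay do not show that it would hold on any further core.

Open, from the compounds shown here alone, is how an amine or a carboxylic acid would compare in the same place. The parts of the difference between the two cores also remain unseparated.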